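The compounds below may be only part of what the source reports. "The series", "measured", "known", "first", "only" and "open" are said of these compounds alone.

Compound 3 `CCCCCCCCCCCCCCCCOC(=O)CCC(=O)N1CCN(CCCOc2cc3c(Nc4ccc(F)c(Cl)c4)ncnc3cc2OC)CC1` stands highest of the three measured in a functional assay on A549 cells (Homo sapiens) for cytotoxicity, read by MTT assay, with a stated time of 24 h, tested at 40 uM (a lower number here means a stronger effect, a higher number a weaker effect of the compound at the concentration tested), where compound 3 gives 82.6%; compound 1 `CCCCCCCOC(=O)CCC(=O)N1CCN(CCCOc2cc3c(Nc4ccc(F)c(Cl)c4)ncnc3cc2OC)CC1` gives 59.1% and compound 2 `CCCCCCCCCOC(=O)CCC(=O)N1CCN(CCCOc2cc3c(Nc4ccc(F)c(Cl)c4)ncnc3cc2OC)CC1` gives 17.9%. Compound 4 `CCCCCCCCCCCCCCCCCCCOC(=O)CCC(=O)N1CCN(CCCOc2cc3c(Nc4ccc(F)c(Cl)c4)ncnc3cc2OC)CC1` differs from compound 3 by propyl in place of hydrogen on a saturated chain carbon, ten or more bonds along the chain from an oxygen next to a carbonyl group. The measured steps along the same chain bear on it: a number 41.2 percentage points lower from compound 1 to compound 2 (beyond the scatter), a number 23.5 percentage points higher from compound 1 to compound 3 (beyond the scatter) and a number 64.7 percentage points higher from compound 2 to compound 3 (beyond the scatter). The numbers do not move in one direction with chain length, so no firm trend can be drawn; still, the two longer chains both read above compound 2, and compound 3 already sits near the top of the read-out. For compound 4 the expected step is a number 3.4 percentage points higher from compound 3 to compound 4 (within the scatter), small and within the scatter. Compound 4 is estimated at 86%, with a range of 66% to 100%.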

Compound 4, a percentage reported as activity, at one concentration (the size of the read-out at that concentration, not a potency): 92.3%
Compound 4: the middle estimate sits 6.3 percentage points below what was measured; measured number inside the range.
By their numbers in this assay, from the lowest: compound 2; then compound 1; then compounds 3 and 4 (each within the scatter of the next).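

In this assay, adding propyl to the chain of compound 3 gives no step beyond the scatter (a number 9.7 percentage points higher from compound 3 to compound 4 (within the scatter)). The two longest chains therefore read alike, and compound 4 stands well clear of both shorter chains (a number 74.4 percentage points higher from compound 2 to compound 4 (beyond the scatter); a number 33.2 percentage points higher from compound 1 to compound 4 (beyond the scatter)), so the low reading of compound 2 does not recur at this chain length. No measurement shown accounts for these readings. Open, as far as these compounds go, are the readings for chains of intermediate length between compound 2 and compound 3, and whether a longer chain, or one ending in an amine or a carboxylic acid, would read differently.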